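Replacing 4-iodophenyl with 3,4-dimethylphenyl

The compounds below may be only part of what the source reports. "The series", "measured", "known", "first", "only" and "open" are said of these compounds alone.

In a functional assay on MDA-MB-231 cells (Homo sapiens) for cytotoxicity, read by MTT assay, with a stated time of 48 h (a higher number here means a weaker inhibitor, a lower number a stronger inhibitor), compound 1 `O=C(NCCCCC(c1ccc(F)cc1)c1ccc(F)cc1)Nc1ccc(Cl)cc1` gives 7680 nM, and compound 2 `O=C(NCCCCC(c1ccc(F)cc1)c1ccc(F)cc1)Nc1ccc([N+](=O)[O-])c(Cl)c1` gives 3470 nM.

Compound 3 `O=C(NCCCCN(c1ccc(F)cc1)c1ccc(F)cc1)Nc1ccc(I)cc1` gives > 20000 nM, which is a limit of the assay and not a number.

Compound 4 `Cc1ccc(NC(=O)NCCCCN(c2ccc(F)cc2)c2ccc(F)cc2)cc1C` has not yet been measured. It differs from compound 3 by one change, 3,4-dimethylphenyl in place of 4-iodophenyl on an amide-type nitrogen.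

Within the data shown here, no measured step starts from compound 3, so the evidence is indirect. Among the measured compounds shown here, the one measured step that bears on the change also exchanges the aryl group on an amide-type nitrogen, with 3-chloro-4-nitrophenyl replacing 4-chlorophenyl. That step, a 2.2-fold lower number from compound 1 to compound 2 (0.35 log units; beyond the scatter), is modest, and it was taken on the core of compound 1 rather than on that of compound 3. On this thin basis, a modest shift is expected, and since compound 3 offers only a limit, any shift that can be read would run towards a lower number in this assay. A result that again reaches the limit would not be surprising.

The estimate for compound 4 is an expected value of 13000 nM, within an expected range of 5000 nM to 30000 nM. This estimate means an expected at least 1.5-fold lower number from compound 3 to compound 4 (0.18 log units; that floor lies within the scatter).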

Compound 4, half-maximal inhibitory concentration: > 20000 nM
Compound 4: a limit, no number; the forecaster's own chance of this, stated with the estimate: 40%; at least 1.5-fold (0.18 log units) between middle value and limit.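

In this assay, among these compounds, compound 3 and compound 4 each stop at a limit of the assay and not at a number, so no step between them can be read: the limit of > 20000 nM in this assay, at which 2 of the 4 values shown sit. The compounds shown leave open how 4-iodophenyl and 3,4-dimethylphenyl compare on this shared core, and whether any group on that amide-type nitrogen would give it a readable value.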